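Swapping the phenyl substituent on a glucagon receptor series

This account rests on a few compounds, and the source may have more. Where it says the series, first, only, none or still open, it means among the compounds named here.

Measured compounds:
compound 1, `CCCCCc1c(C(C)C)nc(C(C)C)c(CO)c1-c1ccc(OC)cc1`, 37%
compound 2, `CCCCCc1c(C(C)C)nc(C(C)C)c(CO)c1-c1ccc(O)cc1`, 24%

In an assay on CHO cells for inhibition of Glucagon receptor (Homo sapiens), tested at 20 uM (on this read-out higher numbers stand for more inhibition at the one concentration tested (going by the name of the read-out) and lower numbers for less inhibition), compound 1 gives 37%. In this assay compound 2 gives 24%, the lowest of the two numbers; the step of a number 13 percentage points lower from compound 1 to compound 2 (beyond the scatter) is modest but beyond the scatter. Compound 3, `CCCCCc1c(C(C)C)nc(C(C)C)c(CO)c1-c1cccc(Cl)c1`, has not yet been measured. Relative to compound 2 the change is 3-chlorophenyl in place of 4-hydroxyphenyl on an aromatic carbon: the 4-hydroxyphenyl leaves and a 3-chlorophenyl enters on the carbon opposite the ring nitrogen. For the measured compounds named here, only one measured step bears on this, namely a number 13 percentage points lower from compound 1 to compound 2 (beyond the scatter), which shows that the hydroxy group went with the lower number. Compound 3 has no such group, so a return toward the number of compound 1, or somewhat beyond it, is the expected direction, with a step of about a number 16 percentage points higher from compound 2 to compound 3 (beyond the scatter). Compound 3 is therefore estimated at 40%, within a range from 20% to 60%.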

Compound 3, a percentage reported as inhibition, at one concentration (the size of the read-out at that concentration, not a potency): 49%
Estimate against measurement, compound 3: 9 percentage points below; the range from low to high includes it.
By their numbers in this assay, from the lowest: compound 2; then compound 1; then compound 3.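

Compound 3 shows that this position, on the carbon opposite the ring nitrogen, accepts a phenyl group carrying a chlorine at its 3 position: in this assay the change from 4-hydroxyphenyl gives a number 25 percentage points higher from compound 2 to compound 3 (beyond the scatter) and is larger than the earlier hydroxy-for-methoxy step. The change from 4-methoxyphenyl also gives a number 12 percentage points higher from compound 1 to compound 3 (beyond the scatter), so the number rises beyond that of the 4-methoxyphenyl compound and does not merely recover what the hydroxy group lost. Nothing shown gives a reason for this rise.

Each of these changes alters both the substituent and its place on the phenyl ring, so the contribution of the chlorine cannot be separated from that of its position. On these data alone, a 4-chlorophenyl, 3-methoxyphenyl or unsubstituted phenyl group at this carbon would address that question, and how an amine or a carboxylic acid on the phenyl ring would behave remains open.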